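A Methyl on the (Carboxymethyl)amino Group

This account rests on a few compounds, and the source may have more. Where it says the series, first, only, none or still open, it means among the compounds named here.

In a functional assay on A549 cells (Homo sapiens) for cytotoxicity, read by MTT assay, with a stated time of 72 h (a lower number here means a stronger inhibitor, a higher number a weaker inhibitor), compound 1 `CC1=CCC[C@H]2[C@](C)(CC3=CC(=O)C=CC3=O)[C@@H](C)CC[C@]12C` gives 30000 nM, and compound 2 `CC1=CCC[C@H]2[C@](C)(CC3=CC(=O)C=C(NCC(=O)O)C3=O)[C@@H](C)CC[C@]12C`, which carries (carboxymethyl)amino in place of hydrogen on a double-bonded ring carbon, gives 46700 nM. The two numbers show a 1.6-fold higher number from compound 1 to compound 2 (0.19 log units; within the scatter), so compound 2 stands level with compound 1. Compound 3 `CC1=CCC[C@H]2[C@](C)(CC3=CC(=O)C=C(N[C@@H](C)C(=O)O)C3=O)[C@@H](C)CC[C@]12C` differs from compound 2 by methyl in place of hydrogen on a saturated chain carbon bound to an amine nitrogen and a carbonyl carbon, which turns (carboxymethyl)amino to (1-carboxyethyl)amino. Within the data shown here, only one measured step bears on this change, and it concerns the whole group rather than this methyl. No shift beyond the scatter is expected in this assay because a 1.6-fold higher number from compound 1 to compound 2 (0.19 log units; within the scatter) is all that the data show. The expected step is a 1.2-fold lower number from compound 2 to compound 3 (0.07 log units; within the scatter). Compound 3 is estimated at 40000 nM, within an expected range of 20000 nM to 80000 nM.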

Compound 3, half-maximal inhibitory concentration: 54300 nM
Compound 3: middle estimate off by 1.4-fold (0.13 log units), on the low side, and the stated range covers the measured number.
By their numbers in this assay, from the lowest: compounds 1, 2 and 3 (each within the scatter of the next).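

In this assay, methyl in place of hydrogen on the saturated chain carbon bound to an amine nitrogen and a carbonyl carbon gives a 1.2-fold higher number from compound 2 to compound 3 (0.07 log units; within the scatter), so this position takes a methyl and the reading stays level with that of the unbranched (carboxymethyl)amino compound. Measured against the unsubstituted core, the (1-carboxyethyl)amino group on the double-bonded ring carbon gives a 1.8-fold higher number from compound 1 to compound 3 (0.26 log units; within the scatter), so this branched group, like the unbranched one before it, stands level with compound 1. No measurement here gives a reason for these readings.

The compounds shown leave open whether the readings stay level with a larger group on this chain carbon, such as ethyl or benzyl, or with the methyl in the mirror-image arrangement. They also leave open what an ester or a primary amide would do in place of the carboxylic acid.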